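Replacing the sulfonyl aryl group of compound 3

This account rests on a few compounds, and the source may have more. Where it says the series, first, only, none or still open, it means among the compounds named here.

In a functional assay on MDA-MB-231 cells (Homo sapiens) for antiproliferative activity, read by MTT assay, with a stated time of 24 h (on this read-out lower numbers stand for stronger inhibition and higher numbers for weaker inhibition), compound 3 (`O=C(O)CC(NS(=O)(=O)c1ccccc1Br)c1ccc(Cl)cc1Cl`) gives > 100000 nM as a limit of the assay. Compound 1 (`O=C(O)CC(NS(=O)(=O)c1ccccc1Br)c1ccccc1`) gives > 100000 nM as a limit too. Compound 2 (`O=C(O)CC(NS(=O)(=O)c1cc(F)cc(F)c1)c1ccccc1`) gives 79300 nM as a true number. Compound 4 (`O=C(O)CC(NS(=O)(=O)c1cc(F)cc(F)c1)c1ccc(Cl)cc1Cl`) differs from compound 3 by 3,5-difluorophenyl in place of 2-bromophenyl on a sulfonyl sulfur in one change, 3,5-difluorophenyl in place of 2-bromophenyl on a sulfonyl sulfur. The measured step that the two limits leave unreadable from compound 1 to compound 3 offers no size to carry over. Compound 2 carries the same 3,5-difluorophenyl group and gives 79300 nM as its value, so a small move toward stronger inhibition is expected in this assay here. The expected step is an at least 1.4-fold lower number from compound 3 to compound 4 (0.15 log units; that floor lies within the scatter) in that direction. Compound 4 is estimated at 70000 nM with an expected range from 30000 nM to 100000 nM for now.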

Compound 4, half-maximal inhibitory concentration: 35700 nM
The estimate for compound 4 lay 2.0-fold (0.29 log units) above the measured number; low and high end bracket the measured number.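

In this assay, for the compounds shown here, the change on the sulfonyl sulfur gives a first readable step at this position, an at least 2.8-fold lower number from compound 3 to compound 4 (0.44 log units; beyond the scatter). The 2,4-dichlorophenyl group also becomes readable with 3,5-difluorophenyl on the sulfonyl sulfur, with a 2.2-fold lower number from compound 2 to compound 4 (0.35 log units; beyond the scatter), whereas the pair carrying 2-bromophenyl gave no size. The step at the sulfonyl sulfur remains a floor rather than a full size: the limit of > 100000 nM in this assay, at which 2 of the 4 values shown sit.

Still open, on these data alone, is whether the gain extends to other groups on the sulfonyl sulfur, such as a pyridine ring or 4-methoxyphenyl. Also open, as far as these compounds go, is how an amide in place of the carboxylic acid would read.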